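The source may hold more compounds than are shown below. What is called first, only, known or untested is meant among the compounds shown, and "the series" means these compounds.

Measured compounds in a functional assay on A549 cells (Homo sapiens) for antiproliferative activity, read by XTT assay, with a stated time of 72 h; a lower number here means a stronger inhibitor, a higher number a weaker inhibitor:

Compound 1, `COc1ccc(-c2cc3ccccc3nc2/C=C/C(=O)c2ccc(F)cc2)cc1`, gives 8320 nM.
Compound 2, `COc1ccc(-c2cc3ccccc3nc2/C=C/C(=O)c2ccc([N+](=O)[O-])cc2)cc1`, gives 6310 nM.
Compound 3, `COc1ccc(-c2cc3ccccc3nc2/C=C/C(=O)c2ccco2)cc1`, gives 6130 nM.

The three measured compounds share one core and differ only in the group on the carbonyl carbon. The three numbers lie close together: the step of a 1.3-fold lower number from compound 1 to compound 2 (0.12 log units; within the scatter) and the step of a 1.4-fold lower number from compound 1 to compound 3 (0.13 log units; within the scatter) are both within the scatter, as is the step of a 1.0-fold lower number from compound 2 to compound 3 (0.01 log units; within the scatter). Compound 3 therefore has the lowest of the three numbers, but nothing separates it from compound 2 or compound 1 beyond the scatter.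

Compound 4, `COc1ccc(-c2cc3ccccc3nc2/C=C/C(=O)c2ccccn2)cc1`, carries the change (pyridin-2-yl in place of furan-2-yl on a carbonyl carbon). Going by the values given here, the steps that bear on this are the exchanges of the aromatic group on the carbonyl carbon among compounds 1, 2 and 3, and none of them moved this assay beyond the scatter. A five-membered aromatic ring with one hetero atom gave the same kind of number as the two six-membered carbon rings with their substituents. On that basis the expected step for compound 4 is a 1.1-fold higher number from compound 3 to compound 4 (0.03 log units; within the scatter), with no direction beyond the scatter. Compound 4 is therefore estimated at 6500 nM in this assay, within a range of 3000 nM to 14000 nM.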

Compound 4, half-maximal inhibitory concentration: 6140 nM
Compound 4: middle estimate off by 1.1-fold (0.02 log units), on the high side; measured number inside the range.
By their numbers in this assay, from the lowest: compounds 3, 4, 2 and 1 (each within the scatter of the next).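

In this assay, the carbonyl carbon now carries a six-membered aromatic ring with 1 hetero atom, and the exchange of furan-2-yl for pyridin-2-yl gives a 1.0-fold higher number from compound 3 to compound 4 (0.00 log units; within the scatter). Against the two substituted phenyl groups, pyridin-2-yl gives a 1.0-fold lower number from compound 2 to compound 4 (0.01 log units; within the scatter) and a 1.4-fold lower number from compound 1 to compound 4 (0.13 log units; within the scatter), so at this position the four groups, whether five-membered or six-membered rings and with or without a hetero atom, cannot be told apart by this read-out. No measurement among the data presented accounts for this lack of separation.

Going by these compounds, what remains open is whether this position would stay as insensitive with something other than an aromatic ring on the carbonyl carbon, such as an amine, a carboxylic acid or a longer alkyl chain. Also open, on these data alone, is whether a change elsewhere on the shared core, for example replacing the methoxy group with a hydroxyl group, would produce a step beyond the scatter in this assay.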